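Anilinomethyl to trifluoromethoxy: an expected step for compound 3

The compounds below may be only part of what the source reports. "The series", "measured", "known", "first", "only" and "open" are said of these compounds alone.

Of the compounds shown here, two on the shared core have been measured so far. In an ADME assay on microsomes from liver (Homo sapiens) for metabolic stability, read by LC-MS, with a stated time of 1 h (on this read-out lower numbers stand for a less stable compound and higher numbers for a more stable compound), compound 1 `O=[N+]([O-])c1cn2c(n1)OC[C@@H](OCc1ccc(-c3cccc(OCc4ccccc4)c3)cc1)C2` gives 64% and compound 2 `O=[N+]([O-])c1cn2c(n1)OC[C@@H](OCc1ccc(-c3ccc(CNc4ccccc4)cc3)cc1)C2` gives 12% as the lower of the two values, with a gap between them that lies beyond the scatter.

Compound 3 `O=[N+]([O-])c1cn2c(n1)OC[C@@H](OCc1ccc(-c3ccc(OC(F)(F)F)cc3)cc1)C2` differs from compound 2 on an aromatic carbon of a six-membered aromatic ring of carbon only, para to a large group, where trifluoromethoxy stands in place of anilinomethyl (trifluoromethoxy in place of anilinomethyl on an aromatic carbon). Going by the values given here, no measured pair isolates this exchange, so the size of the step cannot be read from the data and rests on judgement.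

Compound 2 is the low reference (12%) and compound 1 shows a much higher value on the same core (64%), so a rise is the working expectation. The expected step in this assay is upward and beyond the scatter (a number 60 percentage points higher from compound 2 to compound 3 (beyond the scatter)), although two measured compounds support no pattern. For compound 3 the estimate is 72% in this assay, with an expected range of 48% to 93% for this value.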

Compound 3, percent of the compound remaining: 97%
Estimate against measurement, compound 3: 25 percentage points below, and the stated range ends below it.
By their numbers in this assay, from the lowest: compound 2; then compound 1; then compound 3.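

In this assay, going by these compounds alone, trifluoromethoxy in place of anilinomethyl on an aromatic carbon, para to a large group, gives a number 85 percentage points higher from compound 2 to compound 3 (beyond the scatter) and forms the first pair that differs in one place. The read-out therefore depends strongly on the group at this position, since this single exchange covers most of the scale. Compound 3 reaches 97% with a group that has no ring and no hydrogen-bond donor, whereas anilinomethyl has one of each, but no measurement on hand assigns the step to the ring, the donor or any other feature of the exchange.

One pair cannot show which part of anilinomethyl goes with the low value, and an aminomethyl or a benzyl group in the same place would bear on that question. On these data alone, it also remains open whether methoxy or trifluoromethyl would stand nearer to compound 2 or to compound 3 in this assay, and so whether the high value needs the fluorine atoms or only the loss of the anilinomethyl group.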